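The source may report more compounds than this note shows. Statements on the series, on what has been measured and on what is new or still open speak of the compounds shown alone.

Measured compounds:
compound 1 `Cc1c(C(=O)/C=C/c2cccc([N+](=O)[O-])c2)[n+]([O-])c2ccccc2[n+]1[O-]` — 18000 nM
compound 2 `COc1ccc(/C=C/C(=O)c2c(C)[n+]([O-])c3ccccc3[n+]2[O-])cc1` — 93000 nM

In an ADME assay on HPLF cells (Homo sapiens) for cytotoxicity, with a stated time of 48 h (a higher number here means that more compound is tolerated, a lower number that less compound is tolerated), compound 2 gives 93000 nM, the higher of the two numbers. The nearest compound, compound 1, gives 18000 nM in this assay, and the gap between the two lies beyond the scatter. Compound 3 `COc1ccc(/C=C/C(=O)c2c(C)[n+]([O-])c3ccccc3[n+]2[O-])cc1OC` has not yet been measured in this assay. It differs from compound 2 by methoxy in place of hydrogen on an aromatic carbon. Going by the values given here, no step of this kind stands among the measured compounds, so the data give no guide to the size or direction of the change; the account therefore expects a step from compound 2 to compound 3 that stays within the scatter, namely an expected 1.1-fold lower number from compound 2 to compound 3 (0.04 log units; within the scatter). On that basis compound 3 is estimated to give 85000 nM in this assay, with an expected range from 30000 nM to 220000 nM.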

Compound 3, half-maximal cytotoxic concentration: 156000 nM
The estimate for compound 3 lay 1.8-fold (0.26 log units) below the measured number, and the stated range covers the measured number.
By their numbers in this assay, from the lowest: compound 1; then compounds 2 and 3 (each within the scatter of the next).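

Going by these compounds alone, the one step that can now be read in this assay is a 1.7-fold higher number from compound 2 to compound 3 (0.22 log units; within the scatter), for methoxy in place of hydrogen on an aromatic carbon, ortho to a methoxy group and meta to a large group. At this place, then, the added methoxy gives a number that cannot be told apart from that of compound 2, which compound 1 and compound 2 alone could not show. Nothing in the data accounts for this result.

As far as these compounds go, it remains open whether another group in the same place, such as a hydroxyl, an amine or a carboxylic acid, would give a step beyond the scatter. Also open, from the compounds shown here alone, is whether methoxy in place of hydrogen would give a similar step in compound 1, which carries a nitro group.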